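A few compounds are considered here, and "the series" means these few. Any claim that something is new, unique, unknown or untested is made for them only; others in the source may bear on it.

Compound 1 `COc1ccc(-c2cn(-c3cc(OC)c(OC)c(OC)c3)nn2)cc1O` and compound 2 `COc1ccc(-c2cn(-c3ccc(OC)c(OC)c3)nn2)cc1O` share a core, while compound 3 `COc1ccc(-n2cc(-c3ccc(N)cc3)nn2)cc1` has another; the difference between the two cores is not broken down here. In a functional assay on MDA-MB-231 cells (Homo sapiens) for cytotoxicity, read by MTT assay (a lower number here means a stronger inhibitor, a higher number a weaker inhibitor), compound 1 gives only a limit, > 10000 nM. In this assay compound 2 likewise reaches only a limit, > 100 nM. Compound 3 also stops at a limit in this assay, > 100 nM. The change from compound 2 to compound 1 is methoxy in place of hydrogen on an aromatic carbon, and the step it made, a step that the two limits leave unreadable from compound 2 to compound 1, cannot be read because both values are limits the limit of > 100 nM in this assay, at which 2 of the 3 values shown sit (the limit of > 10000 nM in this assay, at which 1 of the 3 values shown sits). Compound 4 `COc1ccc(-n2cc(-c3ccc(N)cc3)nn2)c(OC)c1` carries the same kind of change, (methoxy in place of hydrogen on an aromatic carbon), though here the entering group sits ortho to a large group and meta to a methoxy group rather than ortho to a methoxy group and meta to a large group. With the step that the two limits leave unreadable from compound 2 to compound 1 unreadable, compound 4 is expected to give about 3000 nM in this assay, between 300 nM and 30000 nM. The step that the limit leaves unreadable from compound 3 to compound 4 is thus estimated to be small, and most likely compound 4 will again return only a limit.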

Compound 4, half-maximal inhibitory concentration: > 10000 nM
Compound 4: a limit, no number (the forecaster's own chance of this, stated with the estimate: 70%); middle value at least 3.3-fold (0.52 log units) from the limit.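

Among these compounds, compound 3 and compound 4 both return only limits in this assay, so no step between them can be read. The compounds shown leave open how far methoxy in place of hydrogen on an aromatic carbon shifts the value.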